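Halogen Swap on a Shared Core: Chloro to Bromo

The compounds below may be only part of what the source reports. "The series", "measured", "known", "first", "only" and "open" are said of these compounds alone.

Compound 2 `OCC(CO)OCn1cc(Cl)c2c(NO)ncnc21` carries a chloro group, and in a functional assay on L1210 cells (Mus musculus) for inhibition (on this read-out higher numbers stand for weaker inhibition and lower numbers for stronger inhibition), compound 2 gives 75000 nM. Compound 1 `OCC(CO)OCn1cc(I)c2c(NO)ncnc21` carries an iodo group in the same place, and in this assay compound 1 gives 39000 nM. Compound 2 therefore stands next to compound 1, separated from it only by a step that falls within the scatter. Compound 3 `OCC(CO)OCn1cc(Br)c2c(NO)ncnc21` has not yet been measured; it differs from compound 2 in one place: bromo in place of chloro on an aromatic carbon. For the measured compounds named here, the only measured step that bears on this change is the earlier swap of one halogen for another, where a 1.9-fold higher number from compound 1 to compound 2 (0.28 log units; within the scatter) was seen, and on that basis no step beyond the scatter is expected in this assay. The step of a 1.4-fold lower number from compound 2 to compound 3 (0.13 log units; within the scatter) is expected to be modest. Compound 3 is expected to give about 55000 nM, with a range from 25000 nM to 120000 nM.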

Compound 3, half-maximal inhibitory concentration: 3700 nM
The estimate for compound 3 lay 15-fold (1.17 log units) above the measured number; measured number below the stated range.
By their numbers in this assay, from the lowest: compound 3; then compounds 1 and 2 (each within the scatter of the next).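

In this assay, this position proves far more sensitive to the choice of halogen than the first pair suggested: bromo gives a large change against chloro (a 20-fold lower number from compound 2 to compound 3 (1.31 log units; beyond the scatter)) and against iodo (an 11-fold lower number from compound 1 to compound 3 (1.02 log units; beyond the scatter)). Compounds 1 and 2 lie within the scatter of each other while compound 3 stands apart, so these halogens cannot be treated as interchangeable here, and swapping one heavy atom for another, with no change in the counted hydrogen-bond donors, acceptors or net charge, is enough to shift the result. Nothing at hand gives a reason for this large step.

On these data alone, whether bromo is unusual at this aromatic carbon remains open, since a methyl, a nitrile or an amine there could match or exceed it. As far as these compounds go, it is also open whether bromo keeps its edge when the side chain of the shared core is replaced by a longer chain.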